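Replacing piperidine by methylpiperazine on a dithiocarbamate

The compounds below may be only part of what the source reports. "The series", "measured", "known", "first", "only" and "open" are said of these compounds alone.

Measured compounds:
compound 1 `Cc1nc(O)c2cc(CS/C(S)=N/CCCN(C)C)ccc2n1` gives 25600 nM
compound 2 `Cc1nc(O)c2cc(CSC(=S)N3CCCCC3)ccc2n1` gives 11300 nM
compound 3 `Cc1nc(O)c2cc(CSC(=S)N3CCc4ccccc4C3)ccc2n1` gives 3300 nM

The three compounds were tested in a functional assay on K562 cells (Homo sapiens) for cytotoxicity; on this read-out lower numbers stand for stronger inhibition and higher numbers for weaker inhibition. Compound 2 stands second highest of the three numbers: its nearest neighbour is compound 1 with a higher number, beyond the scatter, and its furthest is compound 3 with a lower number, also beyond the scatter. Compound 4 `Cc1nc(O)c2cc(CSC(=S)N3CCN(C)CC3)ccc2n1` has not been measured in this assay yet. It differs from compound 2 by 4-methylpiperazin-1-yl in place of piperidin-1-yl on a thiocarbonyl carbon. Among the measured compounds shown here, no step between two measured compounds mirrors this change, so the direction is open. The change is expected to give a step of a 1.2-fold higher number from compound 2 to compound 4 (0.09 log units; within the scatter), that is none beyond the scatter. For compound 4 the estimate is 14000 nM, within a range from 5000 nM to 45000 nM.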

Compound 4, half-maximal inhibitory concentration: 10800 nM
Estimate against measurement, compound 4: 1.3-fold (0.11 log units) above, within the range that was stated.
By their numbers in this assay, from the lowest: compound 3; then compounds 4 and 2 (each within the scatter of the next); then compound 1.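

In this assay, placing 4-methylpiperazin-1-yl in place of piperidin-1-yl on a thiocarbonyl carbon gives a 1.0-fold lower number from compound 2 to compound 4 (0.02 log units; within the scatter) and so leaves compound 2 and compound 4 level on this read-out. Among the compounds shown here, this is the first pair here that differs in one place, and it shows that this position takes the second ring nitrogen and its methyl group with no step beyond the scatter. Nothing at hand explains this result. Still open, on these data alone, is whether a morpholine ring or a piperazine lacking the methyl group would read the same at this position.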